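The compounds below may be only part of what the source reports. "The series", "measured", "known", "first", "only" and "open" are said of these compounds alone.

Compound 1, `O=C(NCc1cn(Cc2ccc(F)cc2)nn1)c1cn(-c2ccccc2)nc1-c1ccccc1`, gives 1600 nM.
Compound 2, `COc1ccc(-c2nn(-c3ccccc3)cc2C(=O)NCc2cn(Cc3ccc(F)cc3)nn2)cc1`, gives 500 nM.
Compound 3, `COc1ccc(Cn2cc(CNC(=O)c3cn(-c4ccccc4)nc3-c3ccc(OC)cc3)nn2)cc1`, gives 450 nM.

These three values come from a functional assay on HeLa cells (Homo sapiens) for antiproliferative activity, read by sulforhodamine B assay, with a stated time of 48 h; a higher number here means a weaker inhibitor of growth, a lower number a stronger inhibitor of growth. Going from compound 1 to compound 2 the change is methoxy in place of hydrogen on an aromatic carbon, and this gave a 3.2-fold lower number from compound 1 to compound 2 (0.51 log units; beyond the scatter). From compound 2 to compound 3 the change is a methoxy in place of fluoro on an aromatic carbon, which gave a 1.1-fold lower number from compound 2 to compound 3 (0.05 log units; within the scatter). Compound 3 stands at the lowest of the three numbers, but its gap to compound 2 lies within the scatter, so the two cannot be put in order.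

Compound 4, `COc1ccc(-c2nn(-c3ccccc3)cc2C(=O)NCc2cn(Cc3ccc(OC)c(OC)c3)nn2)cc1`, is not yet measured in this assay. It differs from compound 3 by methoxy in place of hydrogen on an aromatic carbon. The difference between the core of compound 1 and the core of compound 3 is not broken down here. The change from compound 3 to compound 4 is the same kind of change as that from compound 1 to compound 2, but it is not the same: in compound 2 the new methoxy sits para to a large group, while in compound 4 it sits ortho to a methoxy group and meta to a large group, on the other end of the molecule.

For compound 4 a step of a 1.3-fold lower number from compound 3 to compound 4 (0.11 log units; within the scatter) is expected in this assay, smaller than the earlier one, because the same kind of change in compound 2 gave a 3.2-fold lower number from compound 1 to compound 2 (0.51 log units; beyond the scatter) at a different place, and the end of the molecule changed here tolerated the step of a 1.1-fold lower number from compound 2 to compound 3 (0.05 log units; within the scatter). Compound 4 is thus estimated at 350 nM, between 150 nM and 900 nM.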

Compound 4, concentration for 50% growth inhibition: 800 nM
Beside the measured number, compound 4's estimate is 2.3-fold (0.36 log units) below it; measured number inside the range.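

In this assay, the two cases of methoxy in place of hydrogen on an aromatic carbon do not agree: the same change on two cores in this assay, a 3.2-fold lower number (0.51 log units; beyond the scatter) from compound 1 to compound 2 and a 1.8-fold higher number (0.25 log units; within the scatter) from compound 3 to compound 4, 5.7-fold (0.76 log units) apart, beyond the scatter of two such steps. So a gain seen at one end of the molecule cannot be assumed to carry over to another compound in this series, but a 1.8-fold higher number from compound 3 to compound 4 (0.25 log units; within the scatter) does not show that the new methoxy harms activity either, since that step lies within the scatter, and the two cases differ in the place of the methoxy as well as in the rest of the molecule, so one pair each cannot separate the effect of the place from that of the core. Among these compounds, the larger swap on the same end, 3,4-dimethoxyphenyl in place of 4-fluorophenyl, gives a 1.6-fold higher number from compound 2 to compound 4 (0.20 log units; within the scatter), so among compound 2, compound 3 and compound 4 no step on that end goes beyond the scatter.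

Still open, on these data alone, is whether an amine or a carboxylic acid on that aromatic ring would move the number beyond the scatter. As far as these compounds go, it is also open whether a longer chain in place of the benzyl link would do so.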